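Ring size at the chain carbon in tryptophan dioxygenase inhibition

This account rests on a few compounds, and the source may have more. Where it says the series, first, only, none or still open, it means among the compounds named here.

Measured compounds:
compound 1, `Nc1cccc(CNc2cc(C(F)(F)F)cc3[nH]ncc23)c1`: 68%
compound 2, `FC(F)(F)c1cc(NC[C@H]2CCCCN2)c2cn[nH]c2c1`: 69%
compound 3, `FC(F)(F)c1cc(NCC2CNC2)c2cn[nH]c2c1`: 5%

The three share one core and differ only in the group on a saturated chain carbon bound to a nitrogen on an aromatic ring. In an assay for inhibition of Tryptophan 2,3-dioxygenase (Homo sapiens), with stated times of 10 min and 60 min, tested at 10 uM (a lower number here means a weaker effect, a higher number a stronger effect of the compound at the concentration tested), compound 3 gives the lowest of the three numbers. Its nearest neighbour is compound 1, and the step of a number 63 percentage points lower from compound 1 to compound 3 (beyond the scatter) lies beyond the scatter; the step of a number 64 percentage points lower from compound 2 to compound 3 (beyond the scatter) is of the same size and also beyond the scatter. Compound 1 and compound 2 sit within the scatter of each other, a number 1 percentage points higher from compound 1 to compound 2 (within the scatter).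

Compound 4, `FC(F)(F)c1cc(NC[C@@H]2CCCCN2)c2cn[nH]c2c1`, has not yet been measured in this assay. It differs from compound 3 in one place: piperidin-2-yl in place of azetidin-3-yl on a saturated chain carbon bound to a nitrogen on an aromatic ring. Going by the values given here, the step that bears most directly on this change is a number 64 percentage points lower from compound 2 to compound 3 (beyond the scatter), the same exchange read in the opposite direction; compound 4 carries its defined stereocentre in the other sense than compound 2, and no measured pair shows what that alone does. The account therefore expects a large rise for compound 4, a number 50 percentage points higher from compound 3 to compound 4 (beyond the scatter), with some allowance for the unmeasured stereocentre.

Compound 4 is estimated at 55% in this assay, within a range from 25% to 80%.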

Compound 4, a percentage reported as inhibition, at one concentration (the size of the read-out at that concentration, not a potency): 64%
Estimate against measurement, compound 4: 9 percentage points below, within the range that was stated.
By their numbers in this assay, from the lowest: compound 3; then compounds 4, 1 and 2 (each within the scatter of the next).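

In this assay, the large rise seen with piperidin-2-yl now holds for both drawn configurations: exchanging azetidin-3-yl for this ring gives a number 59 percentage points higher from compound 3 to compound 4 (beyond the scatter). Inverting the stereocentre at the saturated ring carbon, which no earlier pair addressed, gives a number 5 percentage points lower from compound 2 to compound 4 (within the scatter), and this step can be read as a test of configuration alone for one reason: the fact that compounds 2 and 4 differ only in the configuration as drawn. The S form also stays within the scatter of the 3-aminophenyl compound, with a number 4 percentage points lower from compound 1 to compound 4 (within the scatter), so at this concentration the read-out does not separate 3-aminophenyl from either piperidin-2-yl form.

Because each number is a percentage at a single concentration rather than a potency, the compounds shown leave open whether compound 2 and compound 4 would also match in potency. Azetidin-3-yl and piperidin-2-yl differ in both ring size and the ring position bearing the chain, so it remains open which of these matters; a pyrrolidin-2-yl or piperidin-3-yl group on the same chain carbon would help to separate the two.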